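Carbamoyl to ethyl(methyl)carbamoyl on the shared core

The compounds below may be only part of what the source reports. "The series", "measured", "known", "first", "only" and "open" are said of these compounds alone.

Compound 1 `CCN(C)C(=O)N1CCN(C(=S)SCc2cn(Cc3ccc(F)cc3)nn2)CC1` gives 2150 nM in a functional assay on MCF7 cells (Homo sapiens) for cytotoxicity, read by MTT assay, with a stated time of 72 h; on this read-out higher numbers stand for weaker inhibition and lower numbers for stronger inhibition. Compound 2 `Cc1ccc(Cn2cc(CSC(=S)N3CCN(C(N)=O)CC3)nn2)cc1` is recorded in this assay only as a limit, > 128000 nM, not as a number. Compound 2 thus sits at the limit of > 128000 nM in this assay, at which 1 of the 2 values shown sits. Compound 3 `CCN(C)C(=O)N1CCN(C(=S)SCc2cn(Cc3ccc(C)cc3)nn2)CC1` is not yet measured; it differs from compound 2 by ethyl(methyl)amino in place of amino on a carbonyl carbon. Going by the values given here, no measured pair isolates this change. Compound 1 carries the same ethyl(methyl)carbamoyl group and gives 2150 nM, so stronger inhibition is expected. A step beyond the scatter toward stronger inhibition is expected, an at least 21-fold lower number from compound 2 to compound 3 (1.32 log units; beyond the scatter). Compound 3 is estimated at 6000 nM, between 1500 nM and 40000 nM.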

Compound 3, half-maximal inhibitory concentration: 40100 nM
Compound 3: middle estimate off by 6.7-fold (0.82 log units), on the low side, and the stated range ends below it.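

In this assay, going by these compounds alone, ethyl(methyl)amino in place of amino on a carbonyl carbon gives an at least 3.1-fold lower number from compound 2 to compound 3 (0.50 log units; beyond the scatter), the first isolated reading of this change. As far as these compounds go, its full size stays unknown, since compound 2 is recorded only as a limit: the limit of > 128000 nM in this assay, at which 1 of the 3 values shown sits. The aromatic carbon also carries weight: with ethyl(methyl)carbamoyl held constant, methyl in place of fluoro gives a 19-fold higher number from compound 1 to compound 3 (1.27 log units; beyond the scatter), a large step.

From the compounds shown here alone, whether the methyl-to-fluoro step would hold with the carbamoyl group remains open. So does how chloro on the aromatic carbon, or diethylamino on the carbonyl carbon, would read.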